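Trifluoromethyl on the Phenyl Arm: Acid Dissociation Expected Unchanged

The compounds below may be only part of what the source reports. "The series", "measured", "known", "first", "only" and "open" are said of these compounds alone.

Compound 1 `COc1cccc(CNCCCNc2ccnc3cc(C4CCCCC4)ccc23)c1O`: 9.47
Compound 2 `COc1cccc(CNCCCNc2ccnc3cc(-c4ccccc4)ccc23)c1O`: 9.47

For the measured compounds named here, compound 2 stands level with compound 1 in a physicochemical assay for acid dissociation, the one measured step being no change at the digits printed from compound 1 to compound 2 (within the scatter). Going by the values given here, the step to compound 3 `COc1cccc(CNCCCNc2ccnc3cc(-c4ccc(C(F)(F)F)cc4)ccc23)c1O` is trifluoromethyl in place of hydrogen on an aromatic carbon, made on the same six-membered aromatic ring of carbon only that the earlier step had exchanged. Because that earlier step no change at the digits printed from compound 1 to compound 2 (within the scatter) left the read-out untouched, a further change on this ring is expected to do likewise, giving an expected step of a number 0.02 log units lower from compound 2 to compound 3 (within the scatter). For compound 3 the expected value is 9.45, between 9.2 and 9.7.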

Compound 3, acid dissociation constant: 9.47
Compound 3: the middle estimate sits 0.02 log units below what was measured; measured number inside the range.
By their numbers in this assay, from the lowest: compounds 1, 2 and 3 (each within the scatter of the next).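

In this assay trifluoromethyl in place of hydrogen on the phenyl arm, para to a large group, gives no change at the digits printed from compound 2 to compound 3 (within the scatter) and so extends the flat reading from an exchange of the whole arm to a substituent carried on it. The larger exchange of 4-(trifluoromethyl)phenyl in place of cyclohexyl gives no change at the digits printed from compound 1 to compound 3 (within the scatter) and so cyclohexyl, phenyl and 4-(trifluoromethyl)phenyl all read alike at this position. As far as these compounds go, whether an amine or a carboxylic acid on this ring would read the same remains open. Nothing available explains this flat reading.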